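A few compounds are considered here, and "the series" means these few. Any claim that something is new, unique, unknown or untested is made for them only; others in the source may bear on it.

Compound 1 `COc1cc(-c2cc(/C=C/C(=O)c3ccc(Cl)c(Cl)c3)[nH]n2)cc(OC)c1OC`: 90%
Compound 2 `COc1ccc(-c2cc(/C=C/C(=O)c3cc(OC)c(OC)c(OC)c3)[nH]n2)cc1OC`: 91%

Both compounds were run in a functional assay on T47D cells (Homo sapiens) for cytotoxicity, read by sulforhodamine B assay, with a stated time of 48 h, tested at 0.01 uM; on this read-out higher numbers stand for a weaker effect at the one concentration tested and lower numbers for a stronger effect. Of the two numbers, compound 1 gives the lower one, yet compound 2 lies within the scatter of it, so neither can be called the stronger. Compound 3 `COc1ccc(C(=O)/C=C/c2cc(-c3cc(OC)c(OC)c(OC)c3)n[nH]2)cc1OC` has not yet been measured. It differs from compound 1 by 3,4-dimethoxyphenyl in place of 3,4-dichlorophenyl on a carbonyl carbon. Among the measured compounds shown here, no step between measured compounds is available, so the size of the step rests on the two values alone; in this assay a step of none beyond the scatter is expected, no change at the digits printed from compound 1 to compound 3 (within the scatter). Compound 3 is expected to give 90%, with a range from 78% to 100%.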

Compound 3, a percentage reported as activity, at one concentration (the size of the read-out at that concentration, not a potency): 93%
Compound 3: the middle estimate sits 3 percentage points below what was measured; the range from low to high includes it.
By their numbers in this assay, from the lowest: compounds 1, 2 and 3 (each within the scatter of the next).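

Placing 3,4-dimethoxyphenyl in place of 3,4-dichlorophenyl on a carbonyl carbon gives, in this assay, a number 3 percentage points higher from compound 1 to compound 3 (within the scatter). At this position, then, the two substituted phenyl groups cannot be told apart at the one concentration tested, although the groups differ in their atoms and in their hydrogen-bond acceptors. Nothing available bears on why this step is so small. The compounds shown leave open whether an amine or a carboxylic acid on this carbonyl carbon would give a number beyond the scatter of compound 1. They also leave open whether the two phenyl groups would still match at another concentration.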